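The source may report more compounds than this note shows. Statements on the series, on what has been measured and on what is new or still open speak of the compounds shown alone.

In a functional assay on KG-1 cells (Homo sapiens) for inhibition, read by MTT assay, with a stated time of 48 h (on this read-out higher numbers stand for weaker inhibition and lower numbers for stronger inhibition), compound 1 (`O=C(CCCCCNC(=O)Cn1cnc2c(NCc3ccccc3)ncnc21)NO`) gives > 50000 nM, which is a limit of the assay. Compound 2 (`O=C(CCCCCNC(=O)Cn1cnc2c(Nc3ccccc3)ncnc21)NO`) gives > 50000 nM, also a limit. For the measured compounds named here, compound 3 (`O=C(CCCCNC(=O)Cn1cnc2c(Nc3ccccc3)nc(Nc3ccccc3)nc21)NO`) gives 34700 nM, the only value so far that is an actual number. The remaining values sit at the limit of > 50000 nM in this assay, at which 2 of the 3 values shown sit.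

Compound 4 (`O=C(CCCCCNC(=O)Cn1cnc2c(Nc3ccccc3)nc(Nc3ccccc3)nc21)NO`) differs from compound 3 only in the chain: (hydroxycarbamoyl)methyl in place of hydroxycarbamoyl on a saturated chain carbon, four bonds along the chain from an amide-type nitrogen. The change is (hydroxycarbamoyl)methyl in place of hydroxycarbamoyl on a saturated chain carbon, four bonds along the chain from an amide-type nitrogen.

Going by the values given here, no measured step covers this change. Among the compounds with values here, the one available step, a step that the two limits leave unreadable from compound 1 to compound 2, concerns a different part of the molecule and gives no size to carry over. Compound 1 and compound 2 carry the same chain as compound 4, but they also differ from it in the substituents on the shared core, and their limits give no number to compare. The expectation therefore rests on compound 3 at 34700 nM, with no shift beyond the usual scatter in either direction. The expected step is a 1.2-fold lower number from compound 3 to compound 4 (0.06 log units; within the scatter). A result reported only as a limit remains possible. For compound 4 the estimated value is 30000 nM, with an expected range of 12000 nM to 50000 nM.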

Compound 4, half-maximal inhibitory concentration: 3800 nM
The estimate for compound 4 lay 7.9-fold (0.90 log units) above the measured number, outside the stated range (below it).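

For the compounds shown here, the chain position is the first place where a change can be sized: on the shared core of compound 3, (hydroxycarbamoyl)methyl in place of hydroxycarbamoyl on a saturated chain carbon, four bonds along the chain from an amide-type nitrogen, gives a 9.1-fold lower number from compound 3 to compound 4 (0.96 log units; beyond the scatter) in this assay. With the chain held fixed, anilino in place of hydrogen on an aromatic carbon gives an at least 13-fold lower number from compound 2 to compound 4 (1.11 log units; beyond the scatter), so compound 4 is separated by a step beyond the scatter from each of its two single-change neighbours. The step between compound 1 and compound 2 joins two limits of the assay and cannot be read: the limit of > 50000 nM in this assay, at which 2 of the 4 values shown sit.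

Only two chain lengths are shown on the core that carries both anilino groups, so it remains open whether a longer chain would continue the trend, level off or reverse it. Also open, from the compounds shown here alone, is how far the added anilino can be replaced, for example by a morpholine or another simple amine, and whether a carboxylic acid in place of the hydroxycarbamoyl end keeps any of the value of compound 4.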